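Swapping a halogenated phenyl on a shared imidazole-bearing core

A few compounds are considered here, and "the series" means these few. Any claim that something is new, unique, unknown or untested is made for them only; others in the source may bear on it.

Compound 1 `O=C1COc2ccc(-c3[nH]c(-c4ccc(F)cc4)nc3-c3ccccc3)cc2N1` was tested in a functional assay on MV4-11 cells (Homo sapiens) for cytotoxicity, read by colorimetric assay and MTT assay, with a stated time of 3 days, tested at 1 uM (a higher number here means a weaker effect of the compound at the concentration tested, a lower number a stronger effect), where compound 1 gives 108%. Two related compounds were measured alongside it: compound 2 `COc1ccc(-n2cc(-c3ccccc3)c(-c3ccc4c(c3)NC(=O)CO4)n2)cc1` gives 106%, and compound 3 `O=C1COc2ccc(-c3nn(-c4ccccc4)cc3-c3ccccc3)cc2N1` gives 117%. The value of compound 1 lies within the scatter of both the value of compound 2 and the value of compound 3, so the three cannot be ordered against one another. The only change measured between two of these compounds is a number 11 percentage points higher from compound 2 to compound 3 (beyond the scatter), a swap of hydrogen for methoxy that has nothing in common with the change now at hand.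

Compound 4 `O=C1COc2ccc(-c3[nH]c(-c4ccc(Cl)cc4Cl)nc3-c3ccccc3)cc2N1` differs from compound 1 by 2,4-dichlorophenyl in place of 4-fluorophenyl on an aromatic carbon. For the measured compounds named here, no measured step bears on this exchange, and all three measured values sit close together at a level that indicates little effect at the concentration tested. Compound 4 is therefore expected to behave like compound 1, with a step of a number 4 percentage points lower from compound 1 to compound 4 (within the scatter), that is, none beyond the scatter. The estimate for compound 4 is 104%, with a range from 85% to 120%.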

Compound 4, a percentage reported as activity, at one concentration (the size of the read-out at that concentration, not a potency): 109%
Compound 4: the middle estimate sits 5 percentage points below what was measured; the measured number falls inside the stated range.
By their numbers in this assay, from the lowest: compounds 2, 1, 4 and 3 (each within the scatter of the next, the first and the last beyond it).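

In this assay, putting 2,4-dichlorophenyl in place of 4-fluorophenyl on the aromatic carbon between two ring nitrogen atoms gives a number 1 percentage points higher from compound 1 to compound 4 (within the scatter), so this exchange leaves no readable mark on the result. For the compounds shown here, this is the first step measured at this position, and it shows that changing the halogen and adding a second one on this phenyl does not move the compound away from the level of compound 1, where little effect is seen at the concentration tested. Nothing available here gives a reason for this outcome.

From the compounds shown here alone, whether this carbon responds to anything other than a halogenated phenyl remains open, for example a phenyl carrying an amine or a carboxylic acid, or a longer chain in place of the ring. Since both compounds show little effect, this single pair also cannot show whether the position matters in a compound with a stronger effect.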